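The compounds below may be only part of what the source reports. "The series", "measured", "known", "first", "only" and "open" are said of these compounds alone.

Compound 3 `COc1cc(N(C)C)c(NC(=O)c2ncccn2)cc1Nc1nccc(-c2cn(C)c3ccccc23)n1` carries a pyrimidin-2-yl group on the carbonyl carbon of the amide. Going by the values given here, in a functional assay on NCI-H1975 cells (Homo sapiens) for antiproliferative activity, read by MTT assay, with a stated time of 72 h (a lower number here means a stronger inhibitor, a higher number a weaker inhibitor), compound 3 gives 5400 nM, the highest number among the three measured members. Compound 1 `COc1cc(N(C)C)c(NC(=O)c2ccncc2)cc1Nc1nccc(-c2cn(C)c3ccccc23)n1`, with pyridin-4-yl on that carbonyl carbon, gives 1470 nM in this assay, and compound 2 `COc1cc(N(C)C)c(NC(=O)c2ccncn2)cc1Nc1nccc(-c2cn(C)c3ccccc23)n1`, with pyrimidin-4-yl, gives 1250 nM. Within this small set the exchange between the two six-membered heteroaryls of compound 1 and compound 2 leaves the number essentially unchanged, a 1.2-fold lower number from compound 1 to compound 2 (0.07 log units; within the scatter), whereas the move to pyrimidin-2-yl costs a modest amount in both cases: a 3.7-fold higher number from compound 1 to compound 3 (0.57 log units; beyond the scatter) and a 4.3-fold higher number from compound 2 to compound 3 (0.64 log units; beyond the scatter).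

Compound 4 `COc1cc(N(C)C)c(NC(=O)c2c[nH]cn2)cc1Nc1nccc(-c2cn(C)c3ccccc23)n1` is the next variation at the same position: 1H-imidazol-4-yl in place of pyrimidin-2-yl on a carbonyl carbon. Among the compounds with values here, no measured step replaces a six-membered heteroaryl by a five-membered one, so the steps that bear on this change are only those that place compound 3 at the top of the numbers; their size is modest. The expectation is therefore that compound 4 recovers part of that loss, giving a modestly lower number, a 2.2-fold lower number from compound 3 to compound 4 (0.33 log units; beyond the scatter), with the direction not secured by a directly comparable step. Compound 4 is estimated at 2500 nM in this assay, within a range of 900 nM to 7000 nM.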

Compound 4, half-maximal inhibitory concentration: 3120 nM
Estimate against measurement, compound 4: 1.2-fold (0.10 log units) below, and the stated range covers the measured number.
By their numbers in this assay, from the lowest: compounds 2 and 1 (each within the scatter of the next); then compounds 4 and 3 (each within the scatter of the next).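

In this assay, 1H-imidazol-4-yl, a five-membered ring that brings a hydrogen-bond donor to the carbonyl carbon, does not separate from pyrimidin-2-yl (a 1.7-fold lower number from compound 3 to compound 4 (0.24 log units; within the scatter)). Its modest gaps to the other two groups (a 2.5-fold higher number from compound 2 to compound 4 (0.40 log units; beyond the scatter); a 2.1-fold higher number from compound 1 to compound 4 (0.33 log units; beyond the scatter)) divide the four amides into two sets: pyridin-4-yl and pyrimidin-4-yl in one, pyrimidin-2-yl and 1H-imidazol-4-yl in the other, so ring size alone does not set the number, as the six-membered pyrimidin-2-yl shares a set with the five-membered group. Nothing at hand explains this division.

Open, from the compounds shown here alone, is whether the hydrogen on the imidazole ring nitrogen matters at all, which a methyl on that nitrogen would address, and whether a plain phenyl or a saturated amine such as piperidin-4-yl on the carbonyl carbon would fall into either set. Also open, going by these compounds, is whether the same division between these groups would hold if the dimethylamino group or the methoxy group on the shared core were exchanged for something else.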